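A second bromo on compound 2

A few compounds are considered here, and "the series" means these few. Any claim that something is new, unique, unknown or untested is made for them only; others in the source may bear on it.

Measured compounds:
Compound 1 `Cn1cc(-c2nc3ccccc3n2C(=O)c2ccccc2)c2ccccc21`: 42300 nM
Compound 2 `Cn1cc(-c2nc3ccccc3n2C(=O)c2ccccc2)c2cc(Br)ccc21`: 48100 nM

In a functional assay on HepG2 cells (Homo sapiens) for inhibition, read by MTT assay, with a stated time of 24 h (on this read-out lower numbers stand for stronger inhibition of growth and higher numbers for weaker inhibition of growth), compound 2 stands within the scatter of compound 1. Compound 3 `Cn1cc(-c2nc3ccccc3n2C(=O)c2ccccc2Br)c2cc(Br)ccc21` differs from compound 2 by one change: bromo in place of hydrogen on an aromatic carbon. This turns benzoyl into (2-bromophenyl)carbonyl. Going by the values given here, only one measured step bears on it, the same kind of replacement made at another place: a 1.1-fold higher number from compound 1 to compound 2 (0.06 log units; within the scatter). That single step offers only a loose guide, and no change beyond the scatter is expected here. The expected value for compound 3 is 45000 nM, with an estimated range of 25000 nM to 90000 nM. The estimate amounts to a 1.1-fold lower number from compound 2 to compound 3 (0.03 log units; within the scatter).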

Compound 3, concentration for 50% growth inhibition: 72100 nM
Compound 3: middle estimate off by 1.6-fold (0.20 log units), on the low side; the range from low to high includes it.
By their numbers in this assay, from the lowest: compounds 1, 2 and 3 (each within the scatter of the next).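

In this assay, the change from benzoyl to (2-bromophenyl)carbonyl gives a 1.5-fold higher number from compound 2 to compound 3 (0.18 log units; within the scatter) and so stays within the scatter. This shows that this place, ortho to a large group on the six-membered aromatic ring of carbon only, takes a bromo without a step beyond the scatter, and that compound 2 can carry this second bromo on that ring. Nothing given here speaks to what lies behind this step.

On these data alone, whether an amine or a carboxylic acid in this same place would also stay within the scatter of compound 2 remains open. So does the effect of a methoxy group there.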